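The source may hold more compounds than are shown below. What is called first, only, known or untested is meant among the compounds shown, and "the series" means these compounds.

Working notes on the series, read in a physicochemical assay for solubility (on this read-out higher numbers stand for higher solubility and lower numbers for lower solubility), as the only measure. Compound 1 `O=C([C@@H]1CCCN1C(=O)c1ccncc1)N1CCC(NS(=O)(=O)c2cc(S(=O)(=O)c3ccccc3)ccc2C(F)(F)F)CC1` gives 100000 nM as its reading. Compound 2 `CC(C)(C)CCN1CCC[C@H]1C(=O)N1CCC(NS(=O)(=O)c2cc(S(=O)(=O)c3ccccc3)ccc2C(F)(F)F)CC1` gives 12500 nM as its reading, the lowest of the two numbers in hand. For the measured compounds named here, the single measured step is an 8.0-fold lower number from compound 1 to compound 2 (0.90 log units; beyond the scatter) and it lies beyond the scatter. That step put 3,3-dimethylbutyl in place of (pyridin-4-yl)carbonyl on an amine nitrogen in a ring.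

Next in line is compound 3 `O=C([C@@H]1CCCN1Cc1ccccc1)N1CCC(NS(=O)(=O)c2cc(S(=O)(=O)c3ccccc3)ccc2C(F)(F)F)CC1`, and the change to it is phenyl in place of neopentyl on a saturated chain carbon bound to an amine nitrogen in a ring on the shared core. Cut one bond further out, it reads 3,3-dimethylbutyl to benzyl, so a saturated chain carbon stays bound to the amine nitrogen in the ring, and neither group carries a net charge. The step of an 8.0-fold lower number from compound 1 to compound 2 (0.90 log units; beyond the scatter) therefore bears only loosely on this change, and a repeat of its size is not expected. The expected move is slight and upward, and the estimate is a 1.4-fold higher number from compound 2 to compound 3 (0.16 log units; within the scatter) in this assay as a working figure. The estimated reading for compound 3 is 18000 nM within a range of 6000 nM to 55000 nM as a working expectation.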

Compound 3, solubility: 25000 nM
Beside the measured number, compound 3's estimate is 1.4-fold (0.14 log units) below it; the measured number falls inside the stated range.
By their numbers in this assay, from the lowest: compounds 2 and 3 (each within the scatter of the next); then compound 1.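

In this assay, the change from 3,3-dimethylbutyl to benzyl on the amine nitrogen in the ring gives a 2.0-fold higher number from compound 2 to compound 3 (0.30 log units; within the scatter), so at this position phenyl in place of neopentyl on the saturated chain carbon does not separate the two compounds. Measured against the (pyridin-4-yl)carbonyl group of compound 1, benzyl gives a 4.0-fold lower number from compound 1 to compound 3 (0.60 log units; beyond the scatter), so compound 2 and compound 3, the two compounds with a saturated chain carbon on that nitrogen, both stand beyond the scatter from compound 1. Nothing measured here gives a cause for either step.

Compound 1 differs from compound 3 in both the carbonyl and the pyridine ring, so the compounds shown leave open which of the two goes with the higher reading of compound 1, a question that a benzoyl group or a (pyridin-4-yl)methyl group on the same nitrogen would address. Also open, as far as these compounds go, is how a benzyl group carrying a carboxylic acid or an amine on its ring would read in this assay, as the two groups compared at this position, neopentyl and phenyl, are both carbon only and carry no net charge.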